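This account rests on a few compounds, and the source may have more. Where it says the series, first, only, none or still open, it means among the compounds named here.

Of the compounds shown here, three sharing one core have been tested in an ADME assay on HUVEC cells (Homo sapiens) for cytotoxicity, read by MTT assay, with a stated time of 24 h; on this read-out lower numbers stand for higher toxicity in this test and higher numbers for lower toxicity in this test. Compound 1 `O=[N+]([O-])c1ccc(/C=C/c2nnc(-c3ccc4c(c3)OCCO4)o2)cc1` gives 299000 nM. Compound 2 `Clc1ccccc1/C=C/c1nnc(-c2ccc3c(c2)OCCO3)o1` gives 368000 nM, and compound 3 `COc1ccc(/C=C/c2nnc(-c3ccc4c(c3)OCCO4)o2)cc1` gives 312000 nM. Compound 1 stands lowest of the three numbers, with compound 3 nearest and compound 2 furthest, but both gaps lie within the scatter, so no order among the three can be read.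

Compound 4 `C(=C/c1nnc(-c2ccc3c(c2)OCCO3)o1)\c1ccccc1` has not yet been measured in this assay. It differs from compound 1 as follows: hydrogen in place of nitro on an aromatic carbon. Within the data shown here, the one measured step that bears on this change is the exchange of the same nitro group for methoxy, a 1.0-fold higher number from compound 1 to compound 3 (0.02 log units; within the scatter), which stayed within the scatter. The step from compound 2 to compound 3, a 1.2-fold lower number from compound 2 to compound 3 (0.07 log units; within the scatter), also stayed within the scatter. Neither measured step moved the number, so no step beyond the scatter is expected in this assay: a 1.0-fold higher number from compound 1 to compound 4 (0.02 log units; within the scatter). Compound 4 is therefore estimated at 310000 nM, with a range from 160000 nM to 600000 nM.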

Compound 4, half-maximal cytotoxic concentration: 209000 nM
For compound 4 the middle estimate is 1.5-fold (0.17 log units) above the measured one; measured number inside the range.
By their numbers in this assay, from the lowest: compounds 4, 1, 3 and 2 (each within the scatter of the next).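

In this assay, hydrogen in place of nitro on an aromatic carbon para to a large group gives a 1.4-fold lower number from compound 1 to compound 4 (0.16 log units; within the scatter), and hydrogen in place of methoxy gives a 1.5-fold lower number from compound 3 to compound 4 (0.17 log units; within the scatter). Hydrogen in place of chloro gives a 1.8-fold lower number from compound 2 to compound 4 (0.25 log units; within the scatter), so removing any of these three groups, rather than exchanging one for another, still leaves a step within the scatter, and compound 4 cannot be separated from the other compounds. No measurement shown here offers an explanation for these steps.

The compounds leave open whether an amine, a carboxylic acid or a longer chain on this aromatic ring would give a step beyond the scatter. They also leave open whether a group on the other side of the shared core would do so.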